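Acid to methylamide on two CDK8 cores

The source may report more compounds than this note shows. Statements on the series, on what has been measured and on what is new or still open speak of the compounds shown alone.

Measured so far:
compound 1, `O=C(O)COc1ccncc1-c1ccc2ccccc2c1`, 16%
compound 2, `Cn1ncc2cc(-c3cnccc3/C=C/C(=O)O)ccc21`, 102%
compound 3, `CNC(=O)COc1ccncc1-c1ccc2ccccc2c1`, 4%

In an assay on a protein complex for inhibition of CDK8/Cyclin C (Homo sapiens), with a stated time of 1 h, tested at 10 uM (a higher number here means more inhibition at the concentration tested (going by the name of the read-out), a lower number less inhibition), compound 2 gives 102%, the highest of the three, with compound 1 at 16% and compound 3 at 4% both well beyond the scatter below it. How the core of compound 2 differs from the core of compound 1 is not broken down here.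

Compound 3 is compound 1 with one change, (methylamino in place of hydroxy on a carbonyl carbon). The step it made was a number 12 percentage points lower from compound 1 to compound 3 (beyond the scatter).

Compound 4, `CNC(=O)/C=C/c1ccncc1-c1ccc2c(cnn2C)c1`, has not yet been measured in this assay. It is compound 2 with the same kind of change, (methylamino in place of hydroxy on a carbonyl carbon). The surroundings differ: in compound 1 the carbonyl carbon sits on a saturated chain carbon, in compound 2 on a double-bonded chain carbon, so the two changes are of the same kind but not the same.

Within the data shown here, the only measured example of this change is the modest drop from compound 1 to compound 3, made at the low end of the scale. Compound 2 starts from a high number, so a step of the same kind could be wider before it shows, or could be larger on this core. The expectation for compound 4 is a step of a number 37 percentage points lower from compound 2 to compound 4 (beyond the scatter), resting on the small step seen from compound 1 to compound 3 and on the high starting value of compound 2. Compound 4 is therefore estimated at 65%, between 25% and 98%.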

Compound 4, a percentage reported as inhibition, at one concentration (the size of the read-out at that concentration, not a potency): 98%
Beside the measured number, compound 4's estimate is 33 percentage points below it, and the stated range covers the measured number.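

Within this assay, methylamino in place of hydroxy on a carbonyl carbon gives a number 4 percentage points lower from compound 2 to compound 4 (within the scatter), and the size of this step can be set against the one on the other core: the same change on two cores in this assay, a number 12 percentage points lower (beyond the scatter) from compound 1 to compound 3 and a number 4 percentage points lower (within the scatter) from compound 2 to compound 4, 8 percentage points apart, within the scatter of two such steps

On these two pairs, then, the size of the step does not separate the core of compound 1, where the carbonyl carbon sits on a saturated chain carbon, from the core of compound 2, where it sits on a double-bonded chain carbon. Among these compounds, this does not establish that the change transfers evenly across the series: there are only two pairs, one lies low on the scale and the other near its top, and a percentage at one concentration is not a potency, so a shift in potency on the core of compound 2 could go unseen.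

The compounds shown leave open how the core of compound 2 responds to other groups on the same carbonyl carbon, such as dimethylamino, a longer chain on the amine nitrogen, or an unsubstituted amide. They also leave open whether an ester there would behave like the acid or like the methylamide.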